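Nitro in Place of Methoxycarbonyl on an Aromatic Ring

A few compounds are considered here, and "the series" means these few. Any claim that something is new, unique, unknown or untested is made for them only; others in the source may bear on it.

Among the measured compounds shown here, in a functional assay on KB cells (Homo sapiens) for cytotoxicity (a lower number here means a stronger inhibitor, a higher number a weaker inhibitor), compound 2 `COC(=O)c1ccc(C(=O)Nc2cccc3c2N(S(=O)(=O)c2ccc(OC)cc2)CC3)cc1` gives 376 nM, the higher of the two numbers so far, while compound 1 `COc1ccc(S(=O)(=O)N2CCc3cccc(NC(=O)c4cccs4)c32)cc1` gives 47 nM. Compound 3 `COc1ccc(S(=O)(=O)N2CCc3cccc(NC(=O)c4ccc([N+](=O)[O-])cc4)c32)cc1` changes compound 2 at one place: nitro in place of methoxycarbonyl on an aromatic carbon. For the measured compounds named here, the only measured step, an 8.0-fold higher number from compound 1 to compound 2 (0.90 log units; beyond the scatter), is modest and exchanged a whole ring group, so it bears only loosely on this smaller swap and suggests no direction. The expected step is smaller, a 1.3-fold lower number from compound 2 to compound 3 (0.10 log units; within the scatter), within the scatter. Compound 3 is estimated at 300 nM, with an expected range of 90 nM to 900 nM.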

Compound 3, half-maximal inhibitory concentration: 102 nM
Beside the measured number, compound 3's estimate is 2.9-fold (0.47 log units) above it, and the stated range covers the measured number.
By their numbers in this assay, from the lowest: compound 1; then compound 3; then compound 2.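

In this assay, nitro in place of methoxycarbonyl on the same aromatic carbon, para to a large group, gives a 3.7-fold lower number from compound 2 to compound 3 (0.57 log units; beyond the scatter), so the number responds to the group at this position even with the phenyl ring kept. Even so, 4-nitrophenyl in place of thiophen-2-yl on the carbonyl carbon leaves a 2.2-fold higher number from compound 1 to compound 3 (0.34 log units; beyond the scatter), so the thiophen-2-yl compound keeps the lowest number of the three. No measurement here explains the change.

From the compounds shown here alone, whether an amine or a carboxylic acid at this same position would lower the number further remains open.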